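Swapping a Hydroxypiperidine for a Methylpiperazine

A few compounds are considered here, and "the series" means these few. Any claim that something is new, unique, unknown or untested is made for them only; others in the source may bear on it.

Of the compounds shown here, two have been tested in a functional assay on CHO-K1 cells for antagonist activity at melanin-concentrating hormone receptor 1 (Homo sapiens), read by inositol phosphate accumulation; on this read-out higher numbers stand for weaker inhibition and lower numbers for stronger inhibition. Compound 2, `Cc1nc(N2CCC(C)(O)CC2)nc2ccc(NC(=O)COc3ccc(Cl)cc3)cc12`, gives 827 nM, and this is the only plain number among the two results shown. Compound 1, `Cc1nc(N2CCC(O)CC2)nc2ccc(NC(=O)C(C)(C)Oc3ccc(Cl)cc3)cc12`, reached only > 10000 nM, which is a limit of the assay rather than a measured number, namely (the limit of > 10000 nM in this assay, at which 1 of the 2 values shown sits). Within the data shown here, no step between two measured compounds differing in a single place is available, so the pair shows only that compound 2 yields a number where compound 1 does not.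

Compound 3, `Cc1nc(N2CCN(C)CC2)nc2ccc(NC(=O)COc3ccc(Cl)cc3)cc12`, is the next compound to be measured. It differs from compound 2 at one place: 4-methylpiperazin-1-yl in place of 4-hydroxy-4-methylpiperidin-1-yl on an aromatic carbon. Among the measured compounds shown here, with no measured step of a similar kind to lean on, the size of this change is a judgement rather than a reading from the data. The expectation is a modest gain for compound 3 in this assay, expressed as a 1.7-fold lower number from compound 2 to compound 3 (0.22 log units; within the scatter), a step that may not clear the usual scatter. Compound 3 is therefore estimated at 500 nM in this assay, with a likely range from 150 nM to 3000 nM.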

Compound 3, half-maximal inhibitory concentration: 3800 nM
The estimate for compound 3 lay 7.6-fold (0.88 log units) below the measured number; measured number outside the range, above it.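

Among these compounds, this is the first step that changes a single place, and it shows that the group on the aromatic carbon between two ring nitrogen atoms affects the result in this assay: 4-methylpiperazin-1-yl in place of 4-hydroxy-4-methylpiperidin-1-yl gives a 4.6-fold higher number from compound 2 to compound 3 (0.66 log units; beyond the scatter), and a higher number here means weaker inhibition. The swap alters several things at once, since the ring gains a second nitrogen, the hydroxy group and its hydrogen-bond donor leave, and the heavy-atom count changes, so this one step cannot show which of these alterations matters. Nothing measured here accounts for the step.

Still open, as far as these compounds go, is whether the loss of the hydroxy group or the arrival of the ring nitrogen drives the change, and a 4-methylpiperidin-1-yl group at this position, with neither feature, would help to separate the two. A morpholin-4-yl group would add a further comparison, with oxygen in the ring in place of the second nitrogen.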